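The source may hold more compounds than are shown below. What is called first, only, known or untested is meant among the compounds shown, and "the series" means these compounds.

Measured so far:
- compound 1 `CC(=O)Nc1nc(-c2cccc(NS(=O)(=O)c3ccc(Br)cc3)c2)cs1`: 25.6% in a functional assay on A-375 cells (Homo sapiens) for antiproliferative activity, read by trypan blue exclusion, with a stated time of 48 h, tested at 10 uM; a lower number here means a stronger effect, a higher number a weaker effect of the compound at the concentration tested
- compound 2 `CC(=O)Nc1nc(-c2cccc(NS(=O)(=O)c3cccc(Br)c3)c2)cs1`: 36% in this assay
- compound 3 `CC(=O)Nc1nc(-c2cccc(NS(=O)(=O)c3ccc(C#CC4CCCCC4)cc3)c2)cs1`: 1.2% in this assay

Compound 1 stands second highest of the three numbers. Towards compound 2 the step is a number 10.4 percentage points higher from compound 1 to compound 2 (beyond the scatter); towards compound 3 it is a number 24.4 percentage points lower from compound 1 to compound 3 (beyond the scatter), the larger of the two.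

The next compound is compound 4 `CCCCCCc1ccc(S(=O)(=O)Nc2cccc(-c3csc(NC(C)=O)n3)c2)cc1`, which is not yet measured. Relative to compound 1 the change is:

hexyl in place of bromo on an aromatic carbon

Going by the values given here, of the measured steps, only the one to compound 3 bears directly on this change, as it is the one that exchanges the bromo group on an aromatic carbon for a carbon-based group: a number 24.4 percentage points lower from compound 1 to compound 3 (beyond the scatter). The step to compound 2 relocates the bromo group instead and gives no guidance on the replacement itself. Hexyl, like 2-cyclohexylethynyl, enters a chain of six carbon atoms in place of the single bromine, so a lowering of the number beyond the scatter is expected, though not necessarily the full extent seen for compound 3. For compound 4 the expected step is a number 16.6 percentage points lower from compound 1 to compound 4 (beyond the scatter). The estimate for compound 4 in this assay is 9%, with a range from 1% to 24%.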

Compound 4, a percentage reported as activity, at one concentration (the size of the read-out at that concentration, not a potency): <= 1%
Compound 4 ended at the assay's limit; the forecaster's own chance of this, stated with the estimate: 0%; at least 8 percentage points between middle value and limit.
By their numbers in this assay, from the lowest: compound 3; then compound 1; then compound 2. At a limit, below all of these: compound 4.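

In this assay compound 4 reads <= 1%, which is a limit of the assay and not a number: the limit of <= 1% in this assay, at which 1 of the 4 values shown sits.

At this position, on an aromatic carbon para to a large group, hexyl in place of bromo gives a number at least 24.6 percentage points lower from compound 1 to compound 4 (beyond the scatter), so the lowering seen with 2-cyclohexylethynyl also occurs with an open chain that has no ring. Between the two replacements the data show a number at least 0.2 percentage points lower from compound 3 to compound 4 (that floor lies within the scatter), so hexyl and 2-cyclohexylethynyl cannot be ordered here.

Open, as far as these compounds go, is whether a shorter chain such as ethyl lowers the number as far as hexyl does. Also open, from the compounds shown here alone, is whether an amine or a carboxylic acid at the end of the hexyl chain keeps the effect.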